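From Methoxy to Butyl on the Shared Core

The compounds below may be only part of what the source reports. "The series", "measured", "known", "first", "only" and "open" are said of these compounds alone.

In a functional assay on MDA-MB-231 cells (Homo sapiens) for antiproliferative activity, with a stated time of 4 days (on this read-out higher numbers stand for weaker inhibition and lower numbers for stronger inhibition), compound 1 `COc1ccc(-c2[nH]c3ccc(OC)cc3c2C=O)cc1` gives 260 nM and so stands highest of the two numbers available. Compound 2 `COc1ccc(-c2[nH]c3cc(Cl)c(C)cc3c2C=O)cc1` gives 26 nM in this assay and lies lower by a margin beyond the scatter, although it differs from compound 1 in more than one place. Compound 3 `CCCCc1ccc2[nH]c(-c3ccc(OC)cc3)c(C=O)c2c1` is still unmeasured. It departs from compound 1 in one place only: butyl in place of methoxy on an aromatic carbon with butyl in place of methoxy on an aromatic carbon of the core. Among the compounds with values here, no measured pair isolates this change, so the expectation rests on thin ground. Within the data shown here, compound 2 at 26 nM shows only that a number well under that of compound 1 is reachable without this methoxy. What is expected in this assay is a 4.3-fold lower number from compound 1 to compound 3 (0.64 log units; beyond the scatter) toward stronger inhibition and beyond the scatter. For compound 3 the estimated value is 60 nM with an expected range from 12 nM to 300 nM around it.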

Compound 3, half-maximal inhibitory concentration: 6.7 nM
For compound 3 the middle estimate is 9.0-fold (0.95 log units) above the measured one; measured number below the stated range.
By their numbers in this assay, from the lowest: compound 3; then compound 2; then compound 1.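

Within the data shown here, exchanging methoxy for butyl on this aromatic carbon of the core gives in this assay a 39-fold lower number from compound 1 to compound 3 (1.59 log units; beyond the scatter) and thus isolates the effect of this one change, which no earlier pair could do. At this position, which is meta to a fused ring and para to a fused ring, the oxygen of the methoxy group is therefore not required for strong inhibition, and an all-carbon chain that brings no hydrogen-bond acceptor is far better tolerated than the methoxy group in compound 1. No measurement shown here accounts for the size of this step.

The compounds shown leave open how the number changes across chain lengths, since only methoxy and butyl are compared at this carbon. Whether a hexyl chain, a branched tert-butyl group or an amine at the same place would keep this level of inhibition also remains unanswered.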